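The source may report more compounds than this note shows. Statements on the series, on what has been measured and on what is new or still open speak of the compounds shown alone.

Compound 1 `COc1ccc(Cc2cc(-c3cccs3)nn(CC(=O)Nc3ccc(Br)cc3)c2=O)cc1`: in a functional assay on HL-60 cells (Homo sapiens), read by calcium flux (on this read-out higher numbers stand for an effect only at larger amounts of compound and lower numbers for an effect already at smaller amounts), compound 1 gives > 50000 nM, a limit of the assay and not a number.
Compound 2 `Cc1cc(Cc2cccc(F)c2)c(=O)n(CC(=O)Nc2ccc(Br)cc2)n1`: in this assay compound 2 gives > 50000 nM, likewise a limit of the assay.

Compound 2 thus stands at the limit of > 50000 nM in this assay, at which 2 of the 2 values shown sit, and no number for it is known. Compound 3 `COc1ccc(Nc2cc(C)nn(CC(=O)Nc3ccc(Br)cc3)c2=O)cc1` differs from compound 2 by (4-methoxyphenyl)amino in place of 3-fluorobenzyl on an aromatic carbon. For the measured compounds named here, no measured step between these two compounds exists, so the expectation rests on the shared limit alone. In this assay the change is expected to bring no step beyond the scatter in either direction, which is what the estimated step that the limit leaves unreadable from compound 2 to compound 3 means. Compound 3 is accordingly expected to give 60000 nM, in the range 10000 nM to 300000 nM, most likely reported again as a limit.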

Compound 3, half-maximal effective concentration: > 50000 nM
Compound 3: only a limit was reported; the forecaster's own chance of this, stated with the estimate: 80%; the middle value is on the limit's open side.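

Compound 3 gives > 50000 nM in this assay, again a limit of the assay and not a number, so no step between compound 2 and compound 3 can be read: the limit of > 50000 nM in this assay, at which 3 of the 3 values shown sit.

The compounds shown leave open whether any change to the shared core gives a measurable effect in this assay.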